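Coumarin series: swapping the benzimidazole arm for an imine

The source may hold more compounds than are shown below. What is called first, only, known or untested is meant among the compounds shown, and "the series" means these compounds.

Two members of the series have been run in a functional assay, read by spectrophotometry, with a stated time of 1 h; a lower number here means a stronger inhibitor, a higher number a weaker inhibitor. Compound 1 `O=c1cc(/C=N\Nc2ccc([N+](=O)[O-])cc2)c2ccc(OCc3ccccc3)cc2o1` reports only a limit, > 2000000 nM, not a number. Compound 2 `O=c1cc(-c2nc3ccccc3[nH]2)c2ccc(OCc3ccccc3)cc2o1` is recorded as "not active" (no number reported), with no number at all, so it cannot be ranked against compound 1; both simply sit at the inactive end, consistent with the limit of > 2000000 nM in this assay, at which 1 of the 2 values shown sits.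

Compound 3 `O=c1cc(/C=N\c2ccccc2O)c2ccc(OCc3ccccc3)cc2o1` differs from compound 2 by a group of 9 heavy atoms (7 carbon, 1 nitrogen, 1 oxygen; one six-membered aromatic ring of carbon only) in place of a group of 9 heavy atoms (7 carbon, 2 nitrogen; one five-membered aromatic ring with 2 hetero atoms, one six-membered aromatic ring of carbon only), on an aromatic carbon. Nothing measured in the series speaks to what such a change does in this assay, so no direction can be read from the data; the step from compound 2 to compound 3 may be none beyond the scatter, and a weak result is the likeliest outcome.

Compound 3 is therefore expected to land around 1000000 nM in this assay, within roughly 100000 nM to 5000000 nM, with a fair chance that only a limit is reported.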

Compound 3, half-maximal inhibitory concentration: "not active" (no number reported)
For compound 3 the study gives words and no number, and the estimate cannot be compared.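

Compound 2 and compound 3 are both recorded as "not active" with no number, so no step can be read between them. The compounds shown leave open whether the 1H-benzimidazol-2-yl group and the group entering in compound 3 differ at all in this assay, and which change would give a measurable value.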